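A few compounds are considered here, and "the series" means these few. Any claim that something is new, unique, unknown or untested is made for them only; others in the source may bear on it.

In a functional assay on HepG2 cells (Homo sapiens) for inhibition, read by MTT assay, with a stated time of 72 h (on this read-out lower numbers stand for stronger inhibition and higher numbers for weaker inhibition), compound 1 (`O=C(Nc1ccc(F)c(Br)c1)C1CCN(C/C=C/c2ccccc2)CC1`) gives 8190 nM, while compound 2 (`O=C(Nc1ccccn1)C1CCN(C/C=C/c2ccccc2)CC1`) gives 51100 nM, the higher of the two numbers. Compound 3 (`O=C(NCc1ccccc1)C1CCN(C/C=C/c2ccccc2)CC1`) differs from compound 2 as follows: benzyl in place of pyridin-2-yl on an amide-type nitrogen. For the measured compounds named here, only one measured step bears on this place, the modest 6.2-fold higher number from compound 1 to compound 2 (0.80 log units; beyond the scatter), in which pyridin-2-yl replaced 3-bromo-4-fluorophenyl. A step of similar or smaller size toward a lower number is therefore expected in this assay, and the estimated change is a 2.0-fold lower number from compound 2 to compound 3 (0.31 log units; beyond the scatter). The estimate for compound 3 is 25000 nM, with an expected range of 9000 nM to 70000 nM.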

Compound 3, half-maximal inhibitory concentration: > 100000 nM
Compound 3: only a limit was reported (the forecaster's own chance of this, stated with the estimate: 10%); at least 4.0-fold (0.60 log units) between middle value and limit.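

The value for compound 3 is a limit, not a number: the limit of > 100000 nM in this assay, at which 1 of the 3 values shown sits. Replacing 3-bromo-4-fluorophenyl with benzyl gives an at least 12-fold higher number from compound 1 to compound 3 (1.08 log units; beyond the scatter), so benzyl does not restore the lower number of compound 1. Replacing pyridin-2-yl with benzyl gives an at least 1.9-fold higher number from compound 2 to compound 3 (0.29 log units; that floor lies within the scatter), so the order of these two groups stays unsettled.

The compounds shown leave open whether the halogens or the methylene link of benzyl matter more at this amide-type nitrogen. Plain phenyl and 3-bromo-4-fluorobenzyl would separate these two changes.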